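Thiouridine tetraphosphates: lengthening the phosphate chain

The source may report more compounds than this note shows. Statements on the series, on what has been measured and on what is new or still open speak of the compounds shown alone.

Measured so far:
compound 1 `O=c1ccn([C@@H]2O[C@H](COP(=O)(O)OP(=O)(O)OP(=O)(O)OP(=O)(O)O)[C@@H](O)[C@H]2O)c(=S)[nH]1` gives 600 nM in an in vitro functional assay on 1321-N1 cells for agonist activity at P2Y purinoceptor 2 (Homo sapiens), read by scintillation proximity assay and inositol phosphate accumulation; on this read-out higher numbers stand for an effect only at larger amounts of compound and lower numbers for an effect already at smaller amounts
compound 2 `O=c1[nH]c(=S)ccn1[C@@H]1O[C@H](COP(=O)(O)OP(=O)(O)OP(=O)(O)OP(=O)(O)O)[C@@H](O)[C@H]1O` gives 70 nM in this assay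

Compound 1 stands at the highest number of the two. Going by the values given here, the only step recorded is an 8.6-fold lower number from compound 1 to compound 2 (0.93 log units; beyond the scatter), and that change is confined to the heteroaromatic group carried on the saturated ring carbon; the phosphate chain is the same in both compounds.

Compound 3 `O=c1ccn([C@@H]2O[C@H](COP(=O)(O)OP(=O)(O)OP(=O)(O)OP(=O)(O)OP(=O)(O)O)[C@@H](O)[C@H]2O)c(=S)[nH]1` differs from compound 1 in the other half of the molecule: a group of 4 heavy atoms (3 oxygen, 1 phosphorus; no ring) in place of a hydrogen atom, on an oxygen. In plain words the phosphate chain is extended by one further unit while the shared core and the heteroaromatic group are left untouched.

Among the compounds with values here, no measured step bears on this change. Within the data shown here, the single step in hand concerns the base and cannot be carried over to the chain; there is nothing that shows what adding a phosphate unit does in this assay. The working assumption is therefore no step beyond the scatter, with the range opened wide on both sides to reflect the missing precedent. Compound 3 is estimated at 500 nM, between 120 nM and 2500 nM, which corresponds to an expected step of a 1.2-fold lower number from compound 1 to compound 3 (0.08 log units; within the scatter).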

Compound 3, half-maximal effective concentration: 570 nM
Compound 3: middle estimate off by 1.1-fold (0.06 log units), on the low side; the measured number falls inside the stated range.
By their numbers in this assay, from the lowest: compound 2; then compounds 3 and 1 (each within the scatter of the next).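

Notes on the chain: the first reading on this half of the molecule in this assay is a 1.1-fold lower number from compound 1 to compound 3 (0.02 log units; within the scatter). With the heteroaromatic group of compound 1 kept, a group of 4 heavy atoms (3 oxygen, 1 phosphorus) in place of a hydrogen atom on this oxygen does not separate the two compounds on this read-out, so the position accepts one further phosphate unit without a change that can be read. Of the two changes read from compound 1, only the change of heteroaromatic group, an 8.6-fold lower number from compound 1 to compound 2 (0.93 log units; beyond the scatter), lies beyond the scatter. No measurement in hand accounts for this result.

Still open, as far as these compounds go, is whether the same extension of the chain would also leave the number of compound 2 within the scatter, as the two changes have so far been read only singly from compound 1. Also open, from the compounds shown here alone, is how the number responds to a shorter phosphate chain, a still longer one, or a chain carrying a methylene group or an amine.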